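Bis-sulfonamides at the Assay Limit: Compound 1 to Compound 4

This account rests on a few compounds, and the source may have more. Where it says the series, first, only, none or still open, it means among the compounds named here.

Compound 1 `Cc1ccc(S(=O)(=O)Nc2ccc(NS(=O)(=O)c3ccc(F)cc3F)cc2)cc1`: > 100000 nM
Compound 2 `O=S(=O)(Nc1ccc(NS(=O)(=O)c2ccc(F)cc2)cc1)c1ccc(F)cc1`: > 100000 nM
Compound 3 `O=S(=O)(Nc1ccc(Oc2ccccc2)cc1)c1ccc(Br)cc1`: > 100000 nM

In an assay for inhibition of liver carboxylesterase 1 (Homo sapiens), read by spectrophotometry (a higher number here means a weaker inhibitor, a lower number a stronger inhibitor), compound 1 gives > 100000 nM, which is a limit of the assay and not a number. In this assay compound 2 gives > 100000 nM, again a limit rather than a number. In this assay compound 3 gives > 100000 nM, also a limit. So compound 1 stands nowhere in particular among these values: all three sit at the limit of > 100000 nM in this assay, at which 3 of the 3 values shown sit, and none of them can be ranked against another.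

Compound 4 `Cc1ccc(S(=O)(=O)Nc2ccc(NS(=O)(=O)c3ccc(Cl)cc3)cc2)cc1` differs from compound 1 in one place: 4-chlorophenyl in place of 2,4-difluorophenyl on a sulfonyl sulfur. Within the data shown here, no step between measured compounds is known here, so there is no measured change to lean on. With compound 1, compound 2 and compound 3 all sitting at the same limit, the expectation for this change is no step beyond the scatter, and most likely a further limit. Compound 4 is therefore estimated at 100000 nM, with a range from 30000 nM to 300000 nM. That estimate means an expected step of a number no higher from compound 1 to compound 4 (the limit leaves the size open), within the usual scatter.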

Compound 4, inhibition constant: > 100000 nM
Compound 4: only a limit was reported; the forecaster's own chance of this, stated with the estimate: 80%; the middle value sits exactly at the limit.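

In this assay compound 4 gives > 100000 nM, a limit of the assay, and with compound 1 also at a limit, no step between the two can be read: the limit of > 100000 nM in this assay, at which 4 of the 4 values shown sit.

The compounds shown leave open whether 4-chlorophenyl and 2,4-difluorophenyl on a sulfonyl sulfur differ at all in this inhibition.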